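Working notes: chain terminus swap from compound 1 to compound 3

A few compounds are considered here, and "the series" means these few. Any claim that something is new, unique, unknown or untested is made for them only; others in the source may bear on it.

Measured so far:
compound 1, `CCCCCC/C=C/C[C@H]1C[C@@H]([C@@H](O)c2ccccc2)CO[C@@H]1c1ccccc1`, 7400 nM
compound 2, `COc1ccc(/C=C/C[C@@H]2C[C@@H]([C@@H](O)c3ccc(OC)c(OC)c3)CO[C@H]2c2ccccc2)cc1OC`, 16100 nM

Both numbers come from a functional assay on HeLa cells (Homo sapiens) for cytotoxicity, read by WST assay, with a stated time of 48 h; on this read-out higher numbers stand for weaker inhibition and lower numbers for stronger inhibition. Compound 1 holds the lowest number of the two; the nearest is compound 2, whose number is higher by a margin beyond the usual scatter. For the measured compounds named here, no single-point step links the two, since they differ in more than one place, so their values show only that compound 1 sits below compound 2 in this assay, not what any one change contributes.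

Compound 3 `O[C@@H](c1ccccc1)[C@H]1CO[C@H](c2ccccc2)[C@@H](C/C=C/c2ccc(F)cc2)C1` is not yet measured. Its relation to compound 1 is a single change: 4-fluorophenyl in place of hexyl on a double-bonded chain carbon bound to a double-bonded chain carbon. The hexyl gives way to a 4-fluorophenyl on the double-bonded chain carbon bound to a double-bonded chain carbon.

Going by the values given here, for this assay the expected step from compound 1 to compound 3 is a 1.5-fold higher number from compound 1 to compound 3 (0.17 log units; within the scatter), a small rise in the number, about at the edge of the scatter, with no measured pair available to anchor its size. Compound 3 is therefore estimated at 11000 nM, with a range from 4500 nM to 27000 nM.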

Compound 3, half-maximal inhibitory concentration: 8340 nM
The estimate for compound 3 lay 1.3-fold (0.12 log units) above the measured number, and the stated range covers the measured number.
By their numbers in this assay, from the lowest: compounds 1, 3 and 2 (each within the scatter of the next, the first and the last beyond it).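

In this assay, for the compounds shown here, 4-fluorophenyl in place of hexyl on a double-bonded chain carbon bound to a double-bonded chain carbon gives a 1.1-fold higher number from compound 1 to compound 3 (0.05 log units; within the scatter), the first step that isolates a single place. At this position, then, an open six-carbon chain and a six-membered aromatic ring of carbon only bearing fluorine are not told apart by this read-out, so the position takes a large change in the shape of the group with no shift beyond the scatter. Nothing measured alongside these compounds accounts for the two groups reading alike.

The compounds shown leave open whether this flatness extends to other groups at the same place, such as a plain phenyl without fluorine, a longer chain than hexyl, an amine or a carboxylic acid. They also leave unassigned how the gap between compound 1 and compound 2 divides among the several places in which those two differ, and a single-place step at each of those places would be needed to settle it.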